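A few compounds are considered here, and "the series" means these few. Any claim that something is new, unique, unknown or untested is made for them only; others in the source may bear on it.

Compound 1 `ClCc1ccccc1Cn1cnc2c(Cl)nc(Cl)nc21` and compound 2 `ClCc1cccc(Cn2cnc3c(Cl)nc(Cl)nc32)c1` share a core and carry the same atoms joined differently; how their cores differ is not broken down here. In a functional assay on KM12 cells (Homo sapiens) for cytotoxicity, read by sulforhodamine B assay, with a stated time of 48 h (on this read-out lower numbers stand for stronger inhibition of growth and higher numbers for weaker inhibition of growth), compound 1 gives 2950 nM, and in this assay compound 2 gives 3800 nM, two numbers within the usual scatter of each other. Compound 3 `Nc1nc(Cl)c2ncn(Cc3ccccc3CCl)c2n1` is compound 1 with one change, (amino in place of chloro on an aromatic carbon), and in this assay compound 3 gives 38900 nM. That change produced a 13-fold higher number from compound 1 to compound 3 (1.12 log units; beyond the scatter). Compound 4 `Nc1nc(Cl)c2ncn(Cc3cccc(CCl)c3)c2n1` is compound 2 with the same change, (amino in place of chloro on an aromatic carbon), made at the same described place. Among the compounds with values here, because the one measured example of this change gave a 13-fold higher number from compound 1 to compound 3 (1.12 log units; beyond the scatter), a step of similar size is expected from compound 2 to compound 4, namely a 12-fold higher number from compound 2 to compound 4 (1.07 log units; beyond the scatter). Compound 4 is therefore estimated to give 45000 nM in this assay, most likely within 20000 nM to 100000 nM.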

Compound 4, concentration for total growth inhibition: 13200 nM
Compound 4: the middle estimate sits 3.4-fold (0.53 log units) above what was measured; the whole stated range lies above it.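

In this assay amino in place of chloro gives a 3.5-fold higher number from compound 2 to compound 4 (0.54 log units; beyond the scatter) and so again weakens inhibition of growth. The direction of the change therefore carried over from one core to the other, which is all that two pairs can show; they do not explain the difference in size or predict the result on a further core. The size of the step did not carry over: the same change on two cores in this assay, a 13-fold higher number (1.12 log units; beyond the scatter) from compound 1 to compound 3 and a 3.5-fold higher number (0.54 log units; beyond the scatter) from compound 2 to compound 4, 3.8-fold (0.58 log units) apart, beyond the scatter of two such steps

The compounds shown leave open how other groups on the same aromatic carbon, such as a methoxy group or a dimethylamino group, would compare with chloro and amino on these two cores.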